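This account rests on a few compounds, and the source may have more. Where it says the series, first, only, none or still open, it means among the compounds named here.

Measured so far in a functional assay on MCF cells (Homo sapiens) for antiproliferative activity, with a stated time of 72 h; a higher number here means a weaker inhibitor, a lower number a stronger inhibitor:
Compound 1 `OC[C@H]1O[C@@H](n2cnc3c(NCc4ccc(F)cc4F)ncnc32)[C@H](O)[C@@H]1O`: > 166000 nM (a limit)
Compound 2 `OC[C@H]1O[C@@H](n2cnc3c(NCc4ccc(F)c(Cl)c4)ncnc32)[C@H](O)[C@@H]1O`: > 166000 nM (a limit)

Compound 2 thus stands at > 166000 nM, which is a limit and not a number. Compound 3 `Cc1ccc(O)c(CNc2ncnc3c2ncn3[C@@H]2O[C@H](CO)[C@@H](O)[C@H]2O)c1` carries 2-hydroxy-5-methylphenyl in place of 3-chloro-4-fluorophenyl, on a saturated chain carbon bound to a nitrogen on an aromatic ring: 2-hydroxy-5-methylphenyl in place of 3-chloro-4-fluorophenyl on a saturated chain carbon bound to a nitrogen on an aromatic ring. Going by the values given here, the only measured step at this place is a step that the two limits leave unreadable from compound 1 to compound 2. All the evidence so far is the limit of > 166000 nM in this assay, at which 2 of the 2 values shown sit. No clear step is therefore expected in this assay. The expected step is an at least 1.2-fold lower number from compound 2 to compound 3 (0.10 log units; that floor lies within the scatter). Compound 3 is estimated at 130000 nM, with an expected range from 30000 nM to 250000 nM.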

Compound 3, half-maximal inhibitory concentration: > 166000 nM
Compound 3: no number, only a limit; the forecaster's own chance of this, stated with the estimate: 65%; at least 1.2-fold (0.10 log units) between middle value and limit.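

Compound 3, like compound 1 and compound 2, gives only a limit and not a number in this assay, so no step among these three compounds can be read. As far as these compounds go, whether exchanging these substituted phenyl groups changes antiproliferative activity at all remains open.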